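This account rests on a few compounds, and the source may have more. Where it says the series, first, only, none or still open, it means among the compounds named here.

Compound 1 `O=C1C=C(Nc2ccc(Br)cc2)C(=O)c2c1nc1n2[C@H]2OC[C@@H](O)[C@H]2OC1`: 3830 nM
Compound 2 `COc1ccc(NC2=CC(=O)c3nc4n(c3C2=O)[C@H]2OC[C@@H](O)[C@H]2OC4)cc1`: 4780 nM
Compound 3 `O=C1C=C(N2CCCCC2)C(=O)c2c1nc1n2[C@H]2OC[C@@H](O)[C@H]2OC1`: not yet measured

These values come from a functional assay on HeLa cells (Homo sapiens) for inhibition, read by sulforhodamine B assay; a lower number here means a stronger inhibitor, a higher number a weaker inhibitor. Compound 2 stands level with compound 1, since their two numbers lie within the scatter of each other. The next change is made on a double-bonded ring carbon of the shared core: piperidin-1-yl in place of (4-methoxyphenyl)amino on a double-bonded ring carbon. In words, compound 3 carries piperidin-1-yl in place of (4-methoxyphenyl)amino.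

Among the compounds with values here, only one measured step bears on this, and only indirectly. The step of a 1.2-fold higher number from compound 1 to compound 2 (0.10 log units; within the scatter) puts methoxy in place of bromo on an aromatic carbon and stays within the scatter. That step alters a substituent on the aromatic ring, whereas compound 3 loses this ring altogether. Within the data shown here, no measured compound lacks that ring, so the data give no direct size for the change. In this assay, among the measured compounds shown here, the expectation is therefore no step clearly beyond the scatter, with a slight lean towards a higher number and wide uncertainty. The expected step is a 1.5-fold higher number from compound 2 to compound 3 (0.17 log units; within the scatter). The estimate for compound 3 is 7000 nM, with an expected range of 2500 nM to 20000 nM.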

Compound 3, half-maximal inhibitory concentration: > 16000 nM
Compound 3: no number, only a limit (the forecaster's own chance of this, stated with the estimate: 10%); at least 2.2-fold (0.35 log units) between middle value and limit.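

In this assay compound 3 gives no number, only a limit of the assay: the limit of > 16000 nM in this assay, at which 1 of the 3 values shown sits.

Even so, the change can be read, with an at least 3.3-fold higher number from compound 2 to compound 3 (0.52 log units; beyond the scatter) and an at least 4.1-fold higher number from compound 1 to compound 3 (0.62 log units; beyond the scatter). The earlier pair showed only that exchanging bromo for methoxy on the aromatic ring left the number within the scatter, whereas replacing the whole (4-methoxyphenyl)amino or (4-bromophenyl)amino group on the double-bonded ring carbon gives a clearly weaker inhibitor. Going by these compounds, the number at this position therefore responds to the group as a whole, even though it did not respond to the one substituent exchanged on its aromatic ring, and the full size of the loss stays unknown since only a limit is available.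

The compounds shown leave open which part of the change matters, since piperidin-1-yl differs from (4-methoxyphenyl)amino both in losing the aromatic ring and in having no hydrogen-bond donor. A cyclohexylamino group, which keeps the nitrogen-bound hydrogen on a non-aromatic ring, or an N-methyl-N-phenylamino group, which keeps the aromatic ring without that hydrogen, would separate the two.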